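The source may report more compounds than this note shows. Statements on the series, on what has been measured and on what is new or still open speak of the compounds shown alone.

Two compounds built on the same core have been examined in a functional assay on SW480 cells (Homo sapiens) for antiproliferative activity, read by MTT assay, with a stated time of 72 h; on this read-out lower numbers stand for stronger inhibition and higher numbers for weaker inhibition. Compound 1 `O=c1c(CSC(=S)N2CCOCC2)coc2ccccc12` gives 5900 nM in this assay, while compound 2 `COc1ccc2occ(CSC(=S)N3CCCCC3)c(=O)c2c1` gives 6700 nM; the two numbers lie within the scatter of one another, so neither stands apart. Compound 3 `O=c1c(CSC(=S)N2CCCCC2)coc2ccccc12` has not yet been measured. It differs from compound 2 by hydrogen in place of methoxy on an aromatic carbon. Among the compounds with values here, no measured pair isolates this change, so its size cannot be read off directly; a step of no size beyond the scatter is expected, since compound 1, which also carries hydrogen at that position, gives 5900 nM. For compound 3 the expected value in this assay is 6000 nM, with a range from 3000 nM to 12000 nM. This estimate corresponds to an expected step of a 1.1-fold lower number from compound 2 to compound 3 (0.05 log units; within the scatter).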

Compound 3, half-maximal inhibitory concentration: 1200 nM
Estimate against measurement, compound 3: 5.0-fold (0.70 log units) above, and the stated range ends above it.
By their numbers in this assay, from the lowest: compound 3; then compounds 1 and 2 (each within the scatter of the next).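

In this assay, hydrogen in place of methoxy on the aromatic carbon gives a 5.6-fold lower number from compound 2 to compound 3 (0.75 log units; beyond the scatter) and so shows that this position matters when piperidin-1-yl is present. Piperidin-1-yl in place of morpholin-4-yl on the thiocarbonyl carbon gives a 4.9-fold lower number from compound 1 to compound 3 (0.69 log units; beyond the scatter) and so shows that the group at this second site matters as well, which compound 1 and compound 2, differing in two places, could not show. No available evidence bears on either step. From the compounds shown here alone, it remains open whether methoxy would have the same effect alongside morpholin-4-yl, and how a fluorine atom or an ethoxy group at the aromatic carbon would compare.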